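The compounds below may be only part of what the source reports. "The series", "measured", "known", "first", "only" and "open" are said of these compounds alone.

Compound 1 has the structure `C[C@]1(O)C[C@@H](OC(=O)/C=C/c2ccccc2)[C@@H]2C=CO[C@@H](O[C@@H]3O[C@H](CO)[C@@H](O)[C@H](O)[C@H]3O)[C@@H]21`. In a functional assay on HCT-8 cells (Homo sapiens) for cytotoxicity, read by MTT assay, with a stated time of 4 days (a lower number here means a stronger inhibitor, a higher number a weaker inhibitor), compound 1 gives > 10000 nM, which is a limit of the assay rather than a measured number. Compound 2, with structure `COc1cc(C(=O)O[C@@H]2C[C@](C)(O)[C@H]3[C@H](O[C@@H]4O[C@H](CO)[C@@H](O)[C@H](O)[C@H]4O)OC=C[C@H]32)ccc1O[C@@H]1O[C@H](CO)[C@@H](O)[C@H](O)[C@H]1O`, gives > 10000 nM in this assay, again a limit. Compound 3, with structure `COc1cc(C(=O)O[C@@H]2C[C@](C)(O)[C@H]3[C@H](O[C@@H]4O[C@H](CO)[C@@H](O)[C@H](O)[C@H]4O)OC=C[C@H]32)cc(OC)c1O[C@@H]1O[C@@H](C)[C@H](O)[C@@H](O)[C@H]1O`, gives > 10000 nM in this assay, also a limit. Among the compounds with values here, every value seen so far sits at the same place, described by the limit of > 10000 nM in this assay, at which 3 of the 3 values shown sit, so no step between measured compounds can be read from these three.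

Compound 4 has the structure `C[C@]1(O)C[C@@H](OC(=O)CCc2cc(O)ccn2)[C@@H]2C=CO[C@@H](O[C@@H]3O[C@H](CO)[C@@H](O)[C@H](O)[C@H]3O)[C@@H]21`. It differs from compound 1 in one place: 2-(4-hydroxypyridin-2-yl)ethyl in place of 2-phenylethenyl on a carbonyl carbon. Within the data shown here, with no measured step to lean on, the expected step from compound 1 to compound 4 is a step that the limit leaves unreadable from compound 1 to compound 4, nothing beyond the scatter. Compound 4 is therefore expected to give about 15000 nM in this assay, within 5000 nM to 50000 nM.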

Compound 4, half-maximal inhibitory concentration: > 10000 nM
Compound 4: no number, only a limit (the forecaster's own chance of this, stated with the estimate: 80%); the middle value lies beyond the limit too.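

Compound 1 and compound 4 both sit at a limit of the assay, so no step between them can be read: the limit of > 10000 nM in this assay, at which 4 of the 4 values shown sit.

The compounds shown leave open which change, if any, would give a measurable number in this assay.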